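The source may report more compounds than this note shows. Statements on the series, on what has been measured and on what is new or still open speak of the compounds shown alone.

In a functional assay on EKVX cells (Homo sapiens) for inhibition, with a stated time of 48 h (on this read-out lower numbers stand for stronger inhibition of growth and higher numbers for weaker inhibition of growth), compound 1 `COc1c(C(=O)/C=C/c2ccc(Cl)cc2)c(O)c(Br)c2occc12` gives 4180 nM and compound 2 `C=CCc1c(O)c(C(=O)/C=C/c2ccccc2)c(OC)c2ccoc12` gives 6130 nM, so compound 2 sits within the usual scatter of compound 1. Compound 3 `C=CCc1c(O)c(C(=O)/C=C/c2ccc(Cl)cc2)c(OC)c2ccoc12` is compound 2 with a single change, chloro in place of hydrogen on an aromatic carbon, turning phenyl into 4-chlorophenyl. Within the data shown here, no pair of measured compounds shows this change on its own, so the expectation is only tentative. In this assay, the step of a 1.4-fold lower number from compound 2 to compound 3 (0.15 log units; within the scatter) is expected to be small, leaning towards stronger inhibition of growth, and it may stay within the scatter. For compound 3 the estimated value is 4300 nM, with an expected range of 1900 nM to 9500 nM.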

Compound 3, concentration for 50% growth inhibition: 7230 nM
Compound 3: the middle estimate sits 1.7-fold (0.23 log units) below what was measured, within the range that was stated.
By their numbers in this assay, from the lowest: compounds 1, 2 and 3 (each within the scatter of the next).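

In this assay, chloro in place of hydrogen on an aromatic carbon, turning phenyl into 4-chlorophenyl, gives a 1.2-fold higher number from compound 2 to compound 3 (0.07 log units; within the scatter) and so has no effect that can be told from the scatter. Allyl in place of bromo on an aromatic carbon gives a 1.7-fold higher number from compound 1 to compound 3 (0.24 log units; within the scatter) and also stays within the scatter. Nothing further here bears on these results.
Still open, on these data alone, is whether an amine or a carboxylic acid on that same ring carbon would shift the number beyond the scatter. Also open, as far as these compounds go, is what a longer chain in place of allyl would do.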